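The source may report more compounds than this note shows. Statements on the series, on what has been measured and on what is new or still open speak of the compounds shown alone.

In an ADME assay on HUVEC cells (Homo sapiens) for cytotoxicity, read by MTT assay, with a stated time of 24 h (on this read-out lower numbers stand for higher toxicity in this test and higher numbers for lower toxicity in this test), compound 1 (`Brc1cccc(/C=C/c2nnc(-c3ccc4c(c3)OCCO4)o2)c1`) gives 322000 nM and compound 2 (`Cc1ccccc1/C=C/c1nnc(-c2ccc3c(c2)OCCO3)o1`) gives 356000 nM on the same shared core. Compound 2 therefore stands level with compound 1, as the two numbers lie within the usual scatter of each other. Compound 3 (`C(=C/c1nnc(-c2ccc3c(c2)OCCO3)o1)\c1ccccc1`) follows from compound 2 by a single change (hydrogen in place of methyl on an aromatic carbon), hydrogen in place of methyl on an aromatic carbon, so that 2-methylphenyl becomes phenyl. Within the data shown here, only one measured step bears on this. It is a 1.1-fold higher number from compound 1 to compound 2 (0.04 log units; within the scatter) and it concerns the same group, with 2-methylphenyl in place of 3-bromophenyl, and it stayed within the scatter. No measured compound carries the plain phenyl, so this single step is thin support, but it gives no reason to expect a move beyond the scatter in this assay and points in neither direction. Compound 3 is accordingly expected to show only a 1.0-fold lower number from compound 2 to compound 3 (0.02 log units; within the scatter) in this comparison. Compound 3 is estimated at 340000 nM with an expected range from 170000 nM to 680000 nM when it is measured.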

Compound 3, half-maximal cytotoxic concentration: 209000 nM
For compound 3 the middle estimate is 1.6-fold (0.21 log units) above the measured one; the measured number falls inside the stated range.
By their numbers in this assay, from the lowest: compounds 3, 1 and 2 (each within the scatter of the next).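

Taking the substituent off the aromatic ring altogether, in this assay, gives a 1.7-fold lower number from compound 2 to compound 3 (0.23 log units; within the scatter) when hydrogen replaces methyl and a 1.5-fold lower number from compound 1 to compound 3 (0.19 log units; within the scatter) when hydrogen replaces bromo. Among these compounds, the earlier pair compared only two substituted rings, whereas compound 3 adds the plain phenyl as a reference, and neither the 2-methylphenyl of compound 2 nor the 3-bromophenyl of compound 1 can be told apart from it on these numbers, so in this small set the read-out does not show a need for either group at this ring. Nothing available explains the numbers of these three compounds, or tells whether their differences are more than scatter.

The shown compounds carry methyl and bromo at different places on the ring, so they leave open whether either group would read the same at the other's place. They also leave open whether a larger change on this ring, such as an amine, a carboxylic acid or a longer chain, would move the number beyond the scatter, and how changes elsewhere on the shared core would read.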